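Removing One Methoxy Group from Compound 3

The compounds below may be only part of what the source reports. "The series", "measured", "known", "first", "only" and "open" are said of these compounds alone.

Compound 3 `COc1ccc(-c2nc(SCC(=O)c3sc(-c4ccccc4)nc3C)[nH]c(=O)c2C#N)cc1OC` gives the lowest number among the three compounds tested in a functional assay on U-87MG ATCC cells for antiproliferative activity against U-87 MG (Homo sapiens), read by MTT assay, with a stated time of 48 h; on this read-out higher numbers stand for weaker inhibition and lower numbers for stronger inhibition: in that assay compound 3 gives 15300 nM. Compound 1 `COc1ccc(-c2nc(SCC(=O)c3sc(-c4ccccc4)nc3C)[nH]c(=O)c2C#N)cc1` gives 48400 nM, and compound 2 `Cc1nc(-c2ccccc2)sc1C(=O)CSc1nc(-c2ccccc2)c(C#N)c(=O)[nH]1` gives 56600 nM. The steps of a 3.2-fold lower number from compound 1 to compound 3 (0.50 log units; beyond the scatter) and a 3.7-fold lower number from compound 2 to compound 3 (0.57 log units; beyond the scatter) set compound 3 apart from both of them.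

Compound 4 `COc1cccc(-c2nc(SCC(=O)c3sc(-c4ccccc4)nc3C)[nH]c(=O)c2C#N)c1` has not yet been measured. It differs from compound 3 in one place: hydrogen in place of methoxy on an aromatic carbon. Cut one bond further out, the change reads 3,4-dimethoxyphenyl to 3-methoxyphenyl. The closest measured precedent is the step of a 1.2-fold higher number from compound 1 to compound 2 (0.07 log units; within the scatter), where the same kind of change, hydrogen in place of methoxy on an aromatic carbon, left the number within the scatter. The opposite change, methoxy in place of hydrogen on an aromatic carbon, moved the number only modestly in a 3.2-fold lower number from compound 1 to compound 3 (0.50 log units; beyond the scatter). Compound 4 is therefore expected to show a step of a 1.2-fold higher number from compound 3 to compound 4 (0.07 log units; within the scatter) in this assay, no larger than the scatter. Compound 4 is estimated at 18000 nM, with a range from 8000 nM to 40000 nM.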

Compound 4, half-maximal inhibitory concentration: 59700 nM
The estimate for compound 4 lay 3.3-fold (0.52 log units) below the measured number; measured number outside the range, above it.
By their numbers in this assay, from the lowest: compound 3; then compounds 1, 2 and 4 (each within the scatter of the next).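

In this assay, among these compounds, the step of a 3.9-fold higher number from compound 3 to compound 4 (0.59 log units; beyond the scatter) shows that hydrogen in place of methoxy on this ring has no fixed size, and that the methoxy group lost from compound 3 counts for much more here than the one lost from compound 1: the same change on two cores in this assay, a 1.2-fold higher number (0.07 log units; within the scatter) from compound 1 to compound 2 and a 3.9-fold higher number (0.59 log units; beyond the scatter) from compound 3 to compound 4, 3.3-fold (0.52 log units) apart, beyond the scatter of two such steps. A single methoxy group on the phenyl ring does not separate compound 4 from the unsubstituted compound 2, as a 1.1-fold higher number from compound 2 to compound 4 (0.02 log units; within the scatter) shows, and its place on the ring does not separate compound 4 from compound 1, as a 1.2-fold higher number from compound 1 to compound 4 (0.09 log units; within the scatter) shows. Among these four compounds, only the 3,4-dimethoxyphenyl compound 3 stands apart, so the effect of adding one methoxy group depends on what the ring already carries: the same change on two cores in this assay, a 3.2-fold lower number (0.50 log units; beyond the scatter) from compound 1 to compound 3 and a 1.1-fold higher number (0.02 log units; within the scatter) from compound 2 to compound 4, 3.3-fold (0.52 log units) apart, beyond the scatter of two such steps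

The compounds shown leave open whether a different second group on this ring, such as a hydroxyl or a chlorine atom, would match compound 3. They also leave open whether an ethoxy group in place of either methoxy group would do so.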